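The source may hold more compounds than are shown below. What is called first, only, known or untested is meant among the compounds shown, and "the series" means these compounds.

Working notes on the series. The core is shared by compound 1 `O=C1NCCc2nc(C#Cc3cccc(F)c3)sc21`, compound 2 `Fc1cccc(C#Cc2nc3c(s2)CN(C2CCC2)CC3)c1` and compound 3 `O=C(C1CCC1)N1CCc2nc(C#Cc3ccccc3)sc2C1`. In an assay on HEK293 cells for positive allosteric modulation of metabotropic glutamate receptor 5 (Homo sapiens), read by FLIPR, with a stated time of 1 h (a higher number here means that more compound is needed for the effect, a lower number that less compound is needed), compound 1 gives 290 nM. For compound 2 the value in this assay is a limit of the assay, > 10000 nM, not a number. For compound 3 the result in this assay is likewise a limit, > 10000 nM, so compound 3 stands at the edge of what the assay reports, the limit at which two of the three values sit (the limit of > 10000 nM in this assay, at which 2 of the 3 values shown sit). Going by the values given here, no step between two measured compounds that differ in a single place is known, so the size of any change can only be guessed. Compound 4 `O=C(c1cccc(Cl)c1)N1CCc2nc(C#Cc3ccccc3)sc2C1` is the next member to be measured. It differs from compound 3 as follows (3-chlorophenyl in place of cyclobutyl on a carbonyl carbon). Since compound 3 gives only a limit, the step cannot be measured on the usual scale, and it is expected that compound 4 lands near or somewhat inside the limit rather than far from it, a step of an at least 2.0-fold lower number from compound 3 to compound 4 (0.30 log units; that floor lies within the scatter). The estimate for compound 4 in this assay is 5000 nM, with a range from 1000 nM to 20000 nM, and a real chance that only a limit is reported again.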

Compound 4, half-maximal effective concentration: 8.7 nM
For compound 4 the middle estimate is 570-fold (2.76 log units) above the measured one, outside the stated range (below it).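

On a carbonyl carbon whose other neighbours are an amide-type nitrogen in a ring, the substituent alone decides the outcome in this assay: with 3-chlorophenyl in place of cyclobutyl and the rest of the structure unchanged, the result is an at least 1100-fold lower number from compound 3 to compound 4 (3.06 log units; beyond the scatter). Going by these compounds alone, this is the first step that can be read between two compounds differing in a single place, and it shows that this position is far from indifferent to the group it carries. Compound 3 gives only a limit, so the printed step is a floor and its true size stays unknown: the limit of > 10000 nM in this assay, at which 2 of the 4 values shown sit.

The compounds shown do not separate the contribution of the aromatic ring from that of the chlorine, which would take an unsubstituted phenyl, while a pyridine ring or a longer alkyl chain on the same carbonyl carbon would test how widely the position tolerates change. Going by these compounds, compound 1 and compound 2 differ from compound 4 in more than one place, so whether the 3-chlorophenyl group would have the same effect on their structures remains open.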